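This account rests on a few compounds, and the source may have more. Where it says the series, first, only, none or still open, it means among the compounds named here.

Compound 1 `CC1(C)[C@H]2CC[C@]1(C)N(Cc1cn(-c3ccc(F)cc3)nn1)C(=O)C2` gives 90 nM in a functional assay on HepG2 cells (Homo sapiens) for inhibition, read by MTT assay, with a stated time of 24 h; on this read-out lower numbers stand for stronger inhibition and higher numbers for weaker inhibition.
Compound 2 `CC1(C)[C@H]2CC[C@]1(C)N(Cc1cn(-c3ccccc3O)nn1)C(=O)C2` gives 120 nM in this assay.

Going by the values given here, compound 2 stands on the same footing as compound 1 in this assay, as the only measured step shows: a 1.3-fold higher number from compound 1 to compound 2 (0.12 log units; within the scatter). Compound 3 `COc1ccc(-n2cc(CN3C(=O)C[C@@H]4CC[C@@]3(C)C4(C)C)nn2)cc1` differs from compound 2 in one place: 4-methoxyphenyl in place of 2-hydroxyphenyl on an aromatic nitrogen. Among the compounds with values here, the single step bearing on it is a 1.3-fold higher number from compound 1 to compound 2 (0.12 log units; within the scatter), where one aryl group on the same aromatic nitrogen replaced another without moving the number beyond the scatter. A step of the same kind, a 1.1-fold lower number from compound 2 to compound 3 (0.04 log units; within the scatter), is therefore expected here. Compound 3 is estimated at 110 nM in this assay, with a range from 50 nM to 250 nM.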

Compound 3, half-maximal inhibitory concentration: 100 nM
The estimate for compound 3 lay 1.1-fold (0.04 log units) above the measured number; the measured number falls inside the stated range.
By their numbers in this assay, from the lowest: compounds 1, 3 and 2 (each within the scatter of the next).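

In this assay, the swap of 2-hydroxyphenyl for 4-methoxyphenyl on the aromatic nitrogen removes the hydrogen-bond donor of the leaving group, yet the result stays within the scatter (a 1.2-fold lower number from compound 2 to compound 3 (0.08 log units; within the scatter)). On the aromatic carbon, methoxy in place of fluoro also stays within the scatter (a 1.1-fold higher number from compound 1 to compound 3 (0.05 log units; within the scatter)), so this position has so far tolerated all three aryl groups shown. No available evidence accounts for this result. As far as these compounds go, whether an amine, a carboxylic acid or a longer alkoxy chain on the phenyl ring would move the number remains open.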